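The compounds below may be only part of what the source reports. "The series", "measured", "known", "first", "only" and "open" are said of these compounds alone.

Among the compounds with values here, compound 2 `Nc1ccc(OCc2cn(-c3cc(=O)oc4ccc(Br)cc34)nn2)cc1` holds the lowest of the two numbers so far; in a functional assay on MCF7 cells (Homo sapiens) for antiproliferative activity, read by MTT assay, with a stated time of 48 h (on this read-out higher numbers stand for weaker inhibition and lower numbers for stronger inhibition), compound 2 gives 2040 nM, while compound 1 `O=c1cc(-n2cc(COc3ccccc3O)nn2)c2cc(Br)ccc2o1` gives 24800 nM. Within the data shown here, the only step seen, a 12-fold lower number from compound 1 to compound 2 (1.08 log units; beyond the scatter), swaps the whole phenyl substitution pattern and does not bear on compound 3 `COC(=O)c1ccc(OCc2cn(-c3cc(=O)oc4ccc(Br)cc34)nn2)cc1`, which carries methoxycarbonyl in place of amino on an aromatic carbon. Among the measured compounds shown here, with no comparable step in hand, the change is treated as open, with a moderate loss held more likely than a gain. Compound 3 is therefore estimated at 5000 nM (range 1500 nM to 16000 nM), meaning an expected 2.5-fold higher number from compound 2 to compound 3 (0.39 log units; beyond the scatter).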

Compound 3, half-maximal inhibitory concentration: 3130 nM
Beside the measured number, compound 3's estimate is 1.6-fold (0.20 log units) above it, and the stated range covers the measured number.
By their numbers in this assay, from the lowest: compounds 2 and 3 (each within the scatter of the next); then compound 1.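

In this assay, methoxycarbonyl in place of amino on the aromatic carbon para to a large group gives a 1.5-fold higher number from compound 2 to compound 3 (0.19 log units; within the scatter) and so leaves the read-out unresolved between the two groups. This pair tolerates more heavy atoms at this position and the loss of the hydrogen-bond donor without a change beyond the scatter. No measurement available here explains this result. Open, on these data alone, is whether a carboxylic acid, an amide or a longer chain at this position would also stay within the scatter of compound 2.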